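The source may hold more compounds than are shown below. What is called first, only, known or untested is meant among the compounds shown, and "the series" means these compounds.

Compound 2 `CCCCCCCCCCn1nnnc1NC(=O)Nc1c(C(C)C)cccc1C(C)C` gives 180 nM in an assay on microsomes from intestine for inhibition of acyl-CoA:cholesterol acyltransferase (Oryctolagus cuniculus) (on this read-out lower numbers stand for stronger inhibition and higher numbers for weaker inhibition), the higher of the two numbers recorded so far. Compound 1 `CCCCCCCCCCCCN1NN=C(NC(=O)Nc2c(C(C)C)cccc2C(C)C)N1` gives 14 nM in this assay, but it differs from compound 2 in more than one place, so that gap is not a single step. Compound 3 `CCCCCCCCCCCCn1nnnc1NC(=O)Nc1c(C(C)C)cccc1C(C)C` is compound 2 with ethyl in place of hydrogen on a saturated chain carbon, ten or more bonds along the chain from an aromatic nitrogen. Among the measured compounds shown here, no measured pair shows this change by itself; the expectation leans on compound 1, which carries the longer chain and gives 14 nM. A modest step toward a lower number is expected, a 2.6-fold lower number from compound 2 to compound 3 (0.41 log units; beyond the scatter). Compound 3 is estimated at 70 nM, within 20 nM to 250 nM.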

Compound 3, half-maximal inhibitory concentration: 210 nM
Beside the measured number, compound 3's estimate is 3.0-fold (0.48 log units) below it; the measured number falls inside the stated range.
By their numbers in this assay, from the lowest: compound 1; then compounds 2 and 3 (each within the scatter of the next).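

In this assay, ethyl in place of hydrogen on a saturated chain carbon, ten or more bonds along the chain from an aromatic nitrogen, gives a 1.2-fold higher number from compound 2 to compound 3 (0.07 log units; within the scatter) and so leaves the two numbers indistinguishable. At this chain position, the added length alone does not reach the number of compound 1 (14 nM). No measured evidence accounts for this result.

Open, on these data alone, is whether a much shorter chain, or a chain ending in a carboxylic acid or an amine, would move the number away from those of compound 2 and compound 3.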